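Removing the methoxy group from the arylamine side

A few compounds are considered here, and "the series" means these few. Any claim that something is new, unique, unknown or untested is made for them only; others in the source may bear on it.

In a functional assay on the whole organism (strain albino) with Mus musculus as the target, in the maximal electroshock model, with a stated time of 0.5 h (on this read-out higher numbers stand for an effect only at larger amounts of compound and lower numbers for an effect already at smaller amounts), compound 1 `COc1ccccc1Nc1nnc(Nc2nc(-c3ccc([N+](=O)[O-])cc3)cs2)s1` gives 300 mg/kg. Compound 2 `O=[N+]([O-])c1ccc(-c2csc(Nc3nnc(Nc4ccccc4)s3)n2)cc1` gives 100 mg/kg in this assay; the change hydrogen in place of methoxy on an aromatic carbon made a step of a 3.0-fold lower number from compound 1 to compound 2 (0.48 log units; beyond the scatter). Compound 3 `COc1ccc(Nc2nnc(Nc3nc(-c4ccccc4)cs3)s2)cc1` gives 100 mg/kg, level with compound 2 at the digits given and, with it, at the lowest value of the three. The difference between the core of compound 3 and that of compound 1 is not broken down here.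

Compound 4 `c1ccc(Nc2nnc(Nc3nc(-c4ccccc4)cs3)s2)cc1` is not yet measured; it differs from compound 3 by hydrogen in place of methoxy on an aromatic carbon. This is the same kind of change as from compound 1 to compound 2, but not the same: there the methoxy sat ortho to a large group, here it sits para to a large group. A smaller step than a 3.0-fold lower number from compound 1 to compound 2 (0.48 log units; beyond the scatter) is expected, because compound 3 already stands at 100 mg/kg, the same value as compound 2 without a methoxy, and the place of the change differs. Compound 4 is thus expected at 100 mg/kg, within 30 mg/kg to 300 mg/kg. The expected step is no change at the digits printed from compound 3 to compound 4 (within the scatter).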

Compound 4, minimum effective dose: 300 mg/kg
Compound 4: the middle estimate sits 3.0-fold (0.48 log units) below what was measured, within the range that was stated.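

Hydrogen in place of methoxy does not carry over from one core to the other in this assay, and the two steps run in opposite directions: the same change on two cores in this assay, a 3.0-fold lower number (0.48 log units; beyond the scatter) from compound 1 to compound 2 and a 3.0-fold higher number (0.48 log units; beyond the scatter) from compound 3 to compound 4, 9.0-fold (0.95 log units) apart, beyond the scatter of two such steps

With the methoxy para to a large group, the change gives a 3.0-fold higher number from compound 3 to compound 4 (0.48 log units; beyond the scatter), while on the same core hydrogen in place of nitro gives a 3.0-fold higher number from compound 2 to compound 4 (0.48 log units; beyond the scatter). The pairs do not tell whether the nitro group on the core of compound 1 or the different place of the methoxy decides the direction, and two pairs set no rule for any further core.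

Still open, on these data alone, is whether a methoxy at the place it holds in compound 1 would give the same step on the core of compound 3. Also open, as far as these compounds go, is how other groups, such as chloro, hydroxy or an amine, would compare with the methoxy on the phenyl ring of compound 4.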